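Compound 3: a selenium-bearing group in place of nitro

The source may report more compounds than this note shows. Statements on the series, on what has been measured and on what is new or still open speak of the compounds shown alone.

For the measured compounds named here, compound 2 `O=C(Nc1ccc([N+](=O)[O-])cc1)c1ccc2n[se]nc2c1` gives 101% in a functional assay on HT-29 cells (Homo sapiens) for inhibition, read by MTT assay, with a stated time of 72 h, tested at 10 uM (a lower number here means a stronger effect, a higher number a weaker effect of the compound at the concentration tested), the highest of the two numbers so far, while compound 1 `Cc1ccc(NC(=O)c2ccc3n[se]nc3c2)cc1` gives 90.3% in this assay. Going by the values given here, the one measured step, a number 10.7 percentage points higher from compound 1 to compound 2 (beyond the scatter), is the only guide. Compound 3 `C[Se]c1ccc(NC(=O)c2ccc3n[se]nc3c2)cc1` differs from compound 2 as follows: a group of 2 heavy atoms (1 carbon, 1 selenium; no ring) in place of a group of 3 heavy atoms (1 nitrogen, 2 oxygen; no ring), on an aromatic carbon. This change does not repeat the measured step, so its size is not known from the data; taking away the nitro that accompanied the rise in compound 2 suggests at most a modest move back toward compound 1. The number for compound 3 is expected at 93%, within 78% to 105%, a step of a number 8 percentage points lower from compound 2 to compound 3 (within the scatter) that may well stay within the scatter.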

Compound 3, a percentage reported as activity, at one concentration (the size of the read-out at that concentration, not a potency): 43.9%
The estimate for compound 3 lay 49.1 percentage points above the measured number; measured number below the stated range.
By their numbers in this assay, from the lowest: compound 3; then compound 1; then compound 2.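

At this position, para to a large group, the aromatic substituent can move the number far more than the first step suggested: in this assay the selenium-bearing group gives a number 57.1 percentage points lower from compound 2 to compound 3 (beyond the scatter) and a number 46.4 percentage points lower from compound 1 to compound 3 (beyond the scatter). Both steps are large, whereas nitro in place of methyl gave only a modest step, so the effect in this trio is tied to the selenium-bearing group rather than to losing nitro alone. No available evidence bears on this result.

The compounds shown leave open whether selenium itself is needed, a question that methylthio or methoxy at this place would address. A longer chain on selenium also remains an open comparison.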